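Swapping a difluorophenyl for pyridinyl: cytotoxicity expectation

The source may hold more compounds than are shown below. What is called first, only, known or untested is meant among the compounds shown, and "the series" means these compounds.

Compound 1 `Cc1cn(C2CCN(Cc3cccc(Oc4cc(F)cc(F)c4)c3)CC2)c(=O)[nH]c1=O` was tested in an ADME assay on MRC5 cells (Homo sapiens) for cytotoxicity, read by fluorescence and resazurin assay, with a stated time of 3 days; on this read-out lower numbers stand for stronger inhibition and higher numbers for weaker inhibition. Here compound 1 gives > 64000 nM, which is a limit of the assay and not a number. Among the three compounds in this set, compound 1 stands at the limit of > 64000 nM in this assay, at which 1 of the 3 values shown sits. Compound 2 `Cc1cn(C2CCN(Cc3cc(Oc4cc(Cl)cc(Cl)c4)ccn3)CC2)c(=O)[nH]c1=O` belongs to the same series, but in this assay compound 2 shows "not determined" (no result reported). Compound 3 `Cc1cn(C2CCN(Cc3cccc(Oc4ccc(O)cc4)n3)CC2)c(=O)[nH]c1=O` likewise belongs to the series, and in this assay compound 3 shows "not determined" (no result reported). So compound 1 is the only anchor available.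

The compound to be measured next is compound 4 `Cc1cn(C2CCN(Cc3cccc(Oc4cccnc4)c3)CC2)c(=O)[nH]c1=O`. It differs from compound 1 in one place: pyridin-3-yl in place of 3,5-difluorophenyl on an oxygen on an aromatic ring. Going by the values given here, since no step between two measured compounds is available, the size of this change can only be guessed. The expectation is that the step from compound 1 to compound 4 in this assay is none beyond the scatter, meaning the step that the limit leaves unreadable from compound 1 to compound 4 is estimated to be small. Compound 4 is therefore expected to give about 70000 nM, within a range from 30000 nM to 200000 nM, and most likely again only a limit will be reported.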

Compound 4, half-maximal inhibitory concentration: > 64000 nM
Compound 4 gave a limit, no number; the forecaster's own chance of this, stated with the estimate: 75%; the middle value is on the limit's open side.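

In this assay, going by these compounds alone, compound 1 and compound 4 both sit at a limit and not at a number, so no step between them can be read: the limit of > 64000 nM in this assay, at which 2 of the 4 values shown sit.

The compounds shown leave open how far past that limit either compound lies, and whether pyridin-3-yl in place of 3,5-difluorophenyl changes cytotoxicity at all.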